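From pyridin-2-yl to 4-methylpyridin-2-yl: a small solubility step

This account rests on a few compounds, and the source may have more. Where it says the series, first, only, none or still open, it means among the compounds named here.

Compound 1 `COc1ccc(F)cc1N1C(=O)CSC1c1cccc(C(=O)NCCCCn2cccn2)c1`: 50000 nM
Compound 2 `C#Cc1cc(C(=O)NCCCCc2ccccc2)cc(C2SCC(=O)N2c2ccccc2OC)c1`: 10000 nM
Compound 3 `O=C(NCCCCn1cccn1)c1cccc(C2SCC(=O)N2c2ccccn2)c1`: 50000 nM

In a physicochemical assay for solubility, read by turbidimetry, measured as kinetic solubility, at pH 7.4 (on this read-out higher numbers stand for higher solubility and lower numbers for lower solubility), compound 3 stands at 50000 nM, level with compound 1 at the top of the three numbers, while compound 2 reads lower at 10000 nM. Compound 4 `Cc1ccnc(N2C(=O)CSC2c2cccc(C(=O)NCCCCn3cccn3)c2)c1` differs from compound 3 in one place: methyl in place of hydrogen on an aromatic carbon. Within the data shown here, the one measured step at this ring, no change at the digits printed from compound 1 to compound 3 (within the scatter), swapped a whole ring group. Among the measured compounds shown here, no measured step adds a methyl, so the evidence is indirect. Given that step, no shift beyond the scatter is expected in this assay. The estimated step is a 1.3-fold lower number from compound 3 to compound 4 (0.10 log units; within the scatter). For compound 4 the expected value is 40000 nM, with an estimated range of 15000 nM to 60000 nM.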

Compound 4, solubility: 50000 nM
Estimate against measurement, compound 4: 1.3-fold (0.10 log units) below; the range from low to high includes it.
By their numbers in this assay, from the lowest: compound 2; then compounds 1, 3 and 4 (each within the scatter of the next).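

Placing a methyl on the pyridin-2-yl ring, on the carbon opposite the ring nitrogen, gives no change at the digits printed from compound 3 to compound 4 (within the scatter) in this assay, so this position now has a direct test of a small added carbon group. Replacing 5-fluoro-2-methoxyphenyl with 4-methylpyridin-2-yl likewise gives no change at the digits printed from compound 1 to compound 4 (within the scatter) in this assay, matching the earlier swap to the unsubstituted ring. No supporting measurement offers an explanation for these flat steps. Still open, from the compounds shown here alone, is how an amine, a carboxylic acid or a longer carbon chain at this same ring carbon would read.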